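The compounds below may be only part of what the source reports. "The series", "measured", "known", "first", "only" and "open" are said of these compounds alone.

Measured compounds:
Compound 1, `O=C(CC[C@H]1O[C@@H](n2cnc3c(Cl)ncnc32)C[C@@H]1O)c1ccccc1`: in an ADME assay on Huh-7 cells (Homo sapiens) for cytotoxicity, read by XTT assay (on this read-out higher numbers stand for lower toxicity in this test and lower numbers for higher toxicity in this test), compound 1 gives 76300 nM.
Compound 2, `COC(=O)CC[C@H]1O[C@@H](n2cnc3c(Cl)ncnc32)C[C@@H]1O`: in this assay compound 2 gives only a limit of the assay, > 200000 nM.

Compound 2 thus stands at the assay limit of > 200000 nM in this assay, at which 1 of the 2 values shown sits, and carries no number of its own; of the two values shown, only compound 1 is a number. For the measured compounds named here, the one measured step, an at least 2.6-fold higher number from compound 1 to compound 2 (0.41 log units; beyond the scatter), runs from a number to a limit and so sets only a floor on its size. Compound 3, `CON(C)C(=O)CC[C@H]1O[C@@H](n2cnc3c(Cl)ncnc32)C[C@@H]1O`, differs from compound 2 in one place: methoxy(methyl)amino in place of methoxy on a carbonyl carbon. Going by the values given here, no measured step covers a change of this kind, and compound 2 already sits at the limit, so the step for compound 3 in this assay is expected to be none beyond the scatter, that is a number no higher from compound 2 to compound 3 (the limit leaves the size open). Compound 3 is therefore estimated at 200000 nM, with a range from 100000 nM to 400000 nM, most likely again reported as a limit.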

Compound 3, half-maximal cytotoxic concentration: > 200000 nM
Compound 3: no number, only a limit; the forecaster's own chance of this, stated with the estimate: 70%; the middle value sits exactly at the limit.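

Methoxy(methyl)amino in place of phenyl on this carbonyl carbon gives an at least 2.6-fold higher number from compound 1 to compound 3 (0.41 log units; beyond the scatter) in this assay, so methoxy is no longer the only replacement for phenyl with a floor beyond the scatter. Compound 3 gives only a limit of the assay, > 200000 nM, and so adds no number to the series. The step from compound 2 to compound 3 cannot be read, so nothing separates methoxy from methoxy(methyl)amino at this place: the limit of > 200000 nM in this assay, at which 2 of the 3 values shown sit.

For the compounds shown here, how far either group lies past the limit stays open, and the only number remains the one for the phenyl ketone, compound 1. Also open, as far as these compounds go, is whether methyl or cyclohexyl in place of phenyl on this carbonyl carbon would give a number or another limit.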